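A few compounds are considered here, and "the series" means these few. Any claim that something is new, unique, unknown or untested is made for them only; others in the source may bear on it.

Compound 3 `C[C@@H]1CC[C@@H]2[C@@H](C1)O[C@@H](c1ccc(F)cc1)CC2(C)F` gives 68000 nM in an ADME assay on MDCK cells (Canis lupus familiaris) for cytotoxicity, read by MTT assay, with a stated time of 48 h (a lower number here means that less compound is tolerated, a higher number that more compound is tolerated), and compound 2 `C[C@@H]1CC[C@@H]2[C@@H](C1)O[C@@H](c1ccccc1)CC2(C)F` gives 65000 nM, so the two numbers in hand sit within the scatter of each other. In this assay compound 1 `C[C@@H]1CC[C@@H]2[C@@H](C1)O[C@@H](c1ccc([N+](=O)[O-])cc1)CC2(C)O` gives only a limit, > 982000 nM. Among the measured compounds shown here, the single measured step is a 1.0-fold higher number from compound 2 to compound 3 (0.02 log units; within the scatter). Compound 4 `C[C@@H]1CC[C@@H]2[C@@H](C1)O[C@@H](c1ccc([N+](=O)[O-])cc1)CC2(C)F` differs from compound 3 by nitro in place of fluoro on an aromatic carbon. For the measured compounds named here, no measured step exchanges fluoro for nitro; the one step in hand, from compound 2 to compound 3, exchanges hydrogen for fluoro at the same place and stayed within the scatter. Compound 1, which carries nitro, sits at the limit of > 982000 nM in this assay, at which 1 of the 3 values shown sits, but it also differs from compound 4 elsewhere, so its value is weak guidance. Compound 4 is therefore expected to give 150000 nM (range 45000 nM to 982000 nM), an estimated step of a 2.2-fold higher number from compound 3 to compound 4 (0.34 log units; beyond the scatter), with a fair chance that this assay reports a limit.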

Compound 4, half-maximal cytotoxic concentration: > 976000 nM
Compound 4 was reported as a limit (the forecaster's own chance of this, stated with the estimate: 25%); at least 6.5-fold (0.81 log units) between middle value and limit.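

On the aromatic carbon para to a large group, the substituent matters in this assay: nitro in place of fluoro gives an at least 14-fold higher number from compound 3 to compound 4 (1.15 log units; beyond the scatter), and nitro in place of hydrogen gives an at least 15-fold higher number from compound 2 to compound 4 (1.17 log units; beyond the scatter). Among the compounds shown here, the earlier fluoro for hydrogen exchange at this place stayed within the scatter, so nitro gives the first large step here. Compound 4 gives a limit, not a number, and the step from compound 1, which also gives a limit, cannot be read: the limit of > 976000 nM in this assay, at which 1 of the 4 values shown sits.

Going by these compounds, whether an amine or a carboxylic acid at this place also gives a large step remains open. So does whether fluoro or hydroxy on the saturated ring carbon makes any difference alongside nitro.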